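Swapping Benzylamino for Butoxy at a Cytotoxicity Limit

The source may report more compounds than this note shows. Statements on the series, on what has been measured and on what is new or still open speak of the compounds shown alone.

Compound 2 `Nc1nc(NCc2ccccc2)c2ncn(/C=C3/CC3(CO)CO)c2n1` was examined in an ADME assay on MOLT-3 cells (Homo sapiens) for cytotoxicity, with a stated time of 7 days; a lower number here means that less compound is tolerated, a higher number that more compound is tolerated. In this assay compound 2 gives > 20000 nM, which is a limit of the assay rather than a number. Compound 3 `Nc1nc(NC2CC2)c2ncn(/C=C3/CC3(CO)CO)c2n1` likewise gives > 20000 nM, again only a limit. Compound 1 `CC(C)CSc1nc(N)nc2c1ncn2/C=C1/CC1(CO)CO` gives "not determined" (no result reported) in this assay. The change that turns compound 2 into compound 4 `CCCCOc1nc(N)nc2c1ncn2/C=C1/CC1(CO)CO` is butoxy in place of benzylamino on an aromatic carbon. Within the data shown here, the only measured step, a step that the two limits leave unreadable from compound 2 to compound 3, cannot be read in size, and the limit of > 20000 nM in this assay, at which 2 of the 3 values shown sit, shows that the values seen so far sit at that limit. Compound 4 is therefore expected to remain at the same limit. The step that the limit leaves unreadable from compound 2 to compound 4 is expected to be none beyond the scatter. For compound 4 the estimate is 25000 nM, ranging from 12000 nM to 50000 nM.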

Compound 4, half-maximal cytotoxic concentration: > 20000 nM
Compound 4: a limit, no number (the forecaster's own chance of this, stated with the estimate: 85%); the middle value is on the limit's open side.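

Compound 2, compound 3 and compound 4 each give only a limit in this assay, so no step among them can be read: the limit of > 20000 nM in this assay, at which 3 of the 4 values shown sit.

On these data alone, whether benzylamino, cyclopropylamino and butoxy differ at all in this assay stays open.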